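Thiazolidinedione benzyl ethers: triazole aryl swap

The source may hold more compounds than are shown below. What is called first, only, known or untested is meant among the compounds shown, and "the series" means these compounds.

Compound 1 `Cc1nc(COc2ccc(/C=C3\SC(=O)NC3=O)cc2)cs1`, compound 2 `O=C1NC(=O)/C(=C/c2ccc(OCc3csc(-c4ccccc4)n3)cc2)S1` and compound 3 `O=C1NC(=O)/C(=C/c2ccc(OCCSc3nnc(Cc4ccccc4)[nH]3)cc2)S1` share a common core and differ in the group attached through the ether oxygen. In a functional assay on the whole organism (plasma, strain Wistar) with Rattus norvegicus as the target, with a stated time of 15 days, at a dose of 3 mg/kg by the oral route (on this read-out lower numbers stand for a weaker effect and higher numbers for a stronger effect at the one dose given), compound 1 gives 10.4%, compound 2 gives 17.8% and compound 3 gives 18.3%. Compound 3 holds the largest of the three numbers, but its gaps to compound 2 and to compound 1 are both within the scatter, so the three compounds cannot be told apart on this read-out.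

Compound 4 `O=C1NC(=O)/C(=C/c2ccc(OCCSc3nnc(-c4ccccc4[N+](=O)[O-])[nH]3)cc2)S1` follows from compound 3 by one change: 2-nitrophenyl in place of benzyl on an aromatic carbon. Among the measured compounds shown here, the only measured step, a number 7.4 percentage points higher from compound 1 to compound 2 (within the scatter), replaces a small group by an aryl on a five-membered aromatic ring and stays within the scatter; it bears on the present change only loosely, since here one aryl-bearing group replaces another. For the measured compounds named here, no measured pair shows a nitro group. For compound 4 a step of a number 0.3 percentage points lower from compound 3 to compound 4 (within the scatter) is expected in this assay, that is, none beyond the scatter. Compound 4 is therefore estimated at 18%, with a range from 7% to 30%.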

Compound 4, a percentage reported as activity, at one dose (the size of the read-out at that dose, not a potency): 14.6%
Beside the measured number, compound 4's estimate is 3.4 percentage points above it; measured number inside the range.
By their numbers in this assay, from the lowest: compounds 1, 4, 2 and 3 (each within the scatter of the next).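

On the aromatic carbon of the five-membered aromatic ring with 3 nitrogen, 2-nitrophenyl in place of benzyl gives a number 3.7 percentage points lower from compound 3 to compound 4 (within the scatter) in this assay and so leaves the number unresolved from that of the benzyl compound. Among the compounds shown here, this is the first step at this position and the first to bring in a nitro group: the entering group has more heavy atoms and adds 2 hydrogen-bond acceptors, yet no step beyond the scatter follows. No evidence on hand accounts for the small difference that is seen.

From the compounds shown here alone, whether an amine or a carboxylic acid on the phenyl ring would move the number beyond the scatter stays open. So does the effect of a longer chain in place of benzyl at this carbon.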